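The compounds below may be only part of what the source reports. "The series", "measured", "known", "first", "only" and "open" are said of these compounds alone.

In an ADME assay on DU-145 cells (Homo sapiens) for cytotoxicity, read by MTT assay, with a stated time of 72 h (on this read-out higher numbers stand for weaker inhibition and lower numbers for stronger inhibition), compound 1 (`COc1ccc(C2=C(c3cc(OC)c(OC)c(OC)c3)C(=O)C(OC(C)=O)C2)cc1`) gives > 100 ug/mL, which is a limit of the assay and not a number. Compound 2 (`COc1ccc(C2=C(c3cc(OC)c(OC)c(OC)c3)C(=O)C(O)C2)cc1`) gives > 100 ug/mL, again only a limit, so it offers no exact number to start from. Compound 3 (`COc1ccc(C2=C(c3cc(OC)c(OC)c(OC)c3)C(=O)C(O)C2)cc1Cl`) gives a measured number, 40 ug/mL.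

Compound 4 (`COc1ccc(C2=C(c3cc(OC)c(OC)c(OC)c3)C(=O)C(O[SiH2]C(C)(C)C)C2)cc1`) differs from compound 2 by a group of 5 heavy atoms (4 carbon, 1 silicon; no ring) in place of a hydrogen atom, on an oxygen on a saturated carbon. The closest measured change, on the same oxygen, is a step that the two limits leave unreadable from compound 1 to compound 2, so it gives no size to carry over. For the measured compounds named here, the only readable change is an at least 2.5-fold lower number from compound 2 to compound 3 (0.39 log units; beyond the scatter), but that chloro sits on an aromatic carbon and not on the oxygen, so it bears on this change only weakly. On these data alone, with so little to go on, no large step is expected in this assay, and the direction remains open. The estimated step is an at least 1.1-fold lower number from compound 2 to compound 4 (0.04 log units; that floor lies within the scatter). For compound 4 the expected value is 90 ug/mL, with an estimated range from 35 ug/mL to 200 ug/mL.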

Compound 4, half-maximal inhibitory concentration: 28 ug/mL
Compound 4: middle estimate off by 3.2-fold (0.51 log units), on the high side, outside the stated range (below it).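

In this assay the oxygen on a saturated carbon gives its first readable change, as the group of 5 heavy atoms (4 carbon, 1 silicon; no ring) brings an at least 3.5-fold lower number from compound 2 to compound 4 (0.55 log units; beyond the scatter) and also an at least 3.5-fold lower number from compound 1 to compound 4 (0.55 log units; beyond the scatter). Until now, hydrogen and acetyl on this oxygen had both ended at a limit of the assay, and the only readable change lay on an aromatic carbon, so this position is now shown to be able to move the read-out. Both steps are floors and not full sizes, since compound 1 and compound 2 each stand at a limit and not at a number: the limit of > 100 ug/mL in this assay, at which 2 of the 4 values shown sit. The compounds shown leave open whether a plain butyl chain on this oxygen, without silicon, or a longer chain ending in an amine would move the read-out in the same way. They also leave open how this group and the chloro on the aromatic carbon would act together in one compound.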